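This account rests on a few compounds, and the source may have more. Where it says the series, first, only, none or still open, it means among the compounds named here.

In an assay on HEK293 cells for inhibition of acid ceramidase (Rattus norvegicus), read by LC-MS, with a stated time of 30 min (a higher number here means a weaker inhibitor, a lower number a stronger inhibitor), compound 1 `CCCCCCNC(=O)n1cc(C(F)(F)F)c(=O)[nH]c1=O` gives 12 nM. Compound 2 `CCCCCCNC(=O)n1cc(CC)c(=O)[nH]c1=O` gives 733 nM in this assay, and compound 3 `CCCCCCNC(=O)n1cc(N(C)Cc2ccccc2)c(=O)[nH]c1=O` gives 5500 nM. Within the data shown here, the only measured step between two compounds that differ in one place, a 61-fold higher number from compound 1 to compound 2 (1.79 log units; beyond the scatter), is large and lies beyond the scatter. Among the three numbers compound 2 stands second highest: its nearest neighbour is compound 3, whose number is higher than that of compound 2, and its furthest is compound 1, set apart from it by that large step.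

Compound 4 `CCCCCCNC(=O)n1cc(I)c(=O)[nH]c1=O` has not yet been measured. It differs from compound 2 by iodo in place of ethyl on an aromatic carbon. Among the measured compounds shown here, the only measured step that bears on this change is the one from compound 1 to compound 2, which also exchanged the group on this aromatic carbon, and it was large, the ethyl compound being the weaker inhibitor by a wide margin. The data therefore show that the group on this carbon alone can move the number far beyond the scatter, and nothing is known yet about iodo there. On that basis a move toward lower numbers is expected, estimated as an 18-fold lower number from compound 2 to compound 4 (1.26 log units; beyond the scatter). Compound 4 is thus expected to give about 40 nM in this assay, within a range from 8 nM to 200 nM.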

Compound 4, half-maximal inhibitory concentration: 147 nM
Beside the measured number, compound 4's estimate is 3.7-fold (0.57 log units) below it, and the stated range covers the measured number.
By their numbers in this assay, from the lowest: compound 1; then compound 4; then compound 2; then compound 3.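

In this assay, iodo in place of ethyl on this aromatic carbon gives a 5.0-fold lower number from compound 2 to compound 4 (0.70 log units; beyond the scatter) as a modest step, so trifluoromethyl is not the only group shown here that ends up with a lower number than ethyl. Iodo still does not match trifluoromethyl at this carbon, since the exchange gives a 12-fold higher number from compound 1 to compound 4 (1.09 log units; beyond the scatter) as a large step, which places compound 4 clearly apart from both compound 1 and compound 2, with trifluoromethyl lowest, iodo in the middle and ethyl highest of the three, each gap beyond the scatter. No measurement is available that accounts for this order of the three groups.

The compounds shown leave open how chloro, bromo, a nitrile or a simple methyl would fall on this carbon relative to these three groups, and whether a plain amino group would stand nearer to them than the benzyl-bearing amine of compound 3 does. They also leave open whether the same order among trifluoromethyl, iodo and ethyl would hold if the chain on the shared core were replaced by a longer chain.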